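Compound 3: a side-chain swap on a stable pair

The source may hold more compounds than are shown below. What is called first, only, known or untested is meant among the compounds shown, and "the series" means these compounds.

Compound 1 `Cc1nc(-c2nc[nH]n2)ccc1-c1cnc2c(n1)N(CC1CCOCC1)C(=O)CN2`: 100%
Compound 2 `Cc1nc(-c2nc[nH]n2)ccc1-c1cnc2c(n1)N(C(C)C)C(=O)CN2`: 99%

In an ADME assay on S9 fraction from liver (Homo sapiens) for metabolic stability, with a stated time of 60 min (on this read-out higher numbers stand for a more stable compound and lower numbers for a less stable compound), compound 2 gives 99%, within the scatter of compound 1 at 100%. Compound 3 `COCCN1C(=O)CNc2ncc(-c3ccc(-c4nc[nH]n4)nc3C)nc21` is not yet measured. Its structure differs from that of compound 2 as follows: 2-methoxyethyl in place of isopropyl on an amide-type nitrogen in a ring. That is, 2-methoxyethyl stands in place of isopropyl on an amide-type nitrogen in a ring. Among the compounds with values here, the only measured step at this nitrogen is small: a number 1 percentage points lower from compound 1 to compound 2 (within the scatter). No shift beyond the scatter is therefore expected in this assay. The expected change is a number 3 percentage points lower from compound 2 to compound 3 (within the scatter). For compound 3 the estimated value is 96%, with an expected range of 86% to 100%.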

Compound 3, percent of the compound remaining: 100%
Beside the measured number, compound 3's estimate is 4 percentage points below it; the range from low to high includes it.
By their numbers in this assay, from the lowest: compounds 2, 1 and 3 (each within the scatter of the next).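

At this amide-type nitrogen, 2-methoxyethyl adds an oxygen and a hydrogen-bond acceptor that isopropyl lacks, yet this assay shows a number 1 percentage points higher from compound 2 to compound 3 (within the scatter) for this swap. Against the (oxan-4-yl)methyl side chain, the open chain gives no change at the digits printed from compound 1 to compound 3 (within the scatter), so all three side chains at this nitrogen lie within the scatter of one another. No measured evidence bears on why the read-out holds across these side chains.

The compounds shown leave open whether an amine, a carboxylic acid or a longer chain at this nitrogen would stay within that scatter.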